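A few compounds are considered here, and "the series" means these few. Any claim that something is new, unique, unknown or untested is made for them only; others in the source may bear on it.

Four close analogues are compared here. Compound 1 `C=C(Cl)C(=O)Nc1cc(Nc2ncc(C#N)c(-c3cn(C)c4ccccc34)n2)c(OC)cc1N(C)CCN(C)C` and compound 2 `CC/C=C\C(=O)Nc1cc(Nc2ncc(C#N)c(-c3cn(C)c4ccccc34)n2)c(OC)cc1N(C)CCN(C)C` share one core, while compound 3 `C=C(Cl)C(=O)Nc1cc(Nc2nc(C)cc(-c3cn(C)c4ccccc34)n2)c(OC)cc1N(C)CCN(C)C` and the still unmeasured compound 4 `CC/C=C\C(=O)Nc1cc(Nc2nc(C)cc(-c3cn(C)c4ccccc34)n2)c(OC)cc1N(C)CCN(C)C` share another; the difference between the two cores is not broken down here. In a functional assay on NCI-H1975 cells (Homo sapiens) for antiproliferative activity, read by MTT assay, with a stated time of 72 h (on this read-out lower numbers stand for stronger inhibition and higher numbers for weaker inhibition), compound 1 gives 1620 nM, compound 2 gives 1150 nM, and compound 3 gives 2230 nM. The change from compound 1 to compound 2 is but-1-en-1-yl in place of 1-chloroethenyl on a carbonyl carbon, and it brought a 1.4-fold lower number from compound 1 to compound 2 (0.15 log units; within the scatter). Exactly the same change, at the same place, is but-1-en-1-yl in place of 1-chloroethenyl on a carbonyl carbon. Within the data shown here, compound 4 is expected to sit at a 1.4-fold lower number from compound 3 to compound 4 (0.14 log units; within the scatter), a step matching the earlier one, because a 1.4-fold lower number from compound 1 to compound 2 (0.15 log units; within the scatter) is the only guide available. On that basis compound 4 is estimated at 1600 nM, with a likely range from 800 nM to 3200 nM.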

Compound 4, half-maximal inhibitory concentration: 1990 nM
Beside the measured number, compound 4's estimate is 1.2-fold (0.09 log units) below it; measured number inside the range.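

In this assay, but-1-en-1-yl in place of 1-chloroethenyl on a carbonyl carbon brought a 1.1-fold lower number from compound 3 to compound 4 (0.05 log units; within the scatter). Set beside the same change on the other core, the step agrees with the earlier one: the same change on two cores in this assay, a 1.4-fold lower number (0.15 log units; within the scatter) from compound 1 to compound 2 and a 1.1-fold lower number (0.05 log units; within the scatter) from compound 3 to compound 4, 1.3-fold (0.10 log units) apart, within the scatter of two such steps. This shows that on these two cores the change made no clear difference, but it does not show a real effect that carries from one core to another, and two cores cannot speak for the wider series.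

Left open is how a plain ethenyl group, or a butenyl chain ending in a dimethylamino group, would read on that carbonyl carbon on either core.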